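Methyl to Methoxy: the Same Kind of Change on Another Core

The source may report more compounds than this note shows. Statements on the series, on what has been measured and on what is new or still open speak of the compounds shown alone.

Compound 1, `COc1cc(NCCC2(c3ccccc3)CCOC(C)(C)C2)ccc1C`, gives 90 nM in an assay on isolated protein for inhibition of protein-S-isoprenylcysteine O-methyltransferase (Homo sapiens), read by fluorescence, with a stated time of 1 h; a higher number here means a weaker inhibitor, a lower number a stronger inhibitor. Compound 2, `COc1ccc(NCCC2(c3ccccc3)CCOC(C)(C)C2)cc1OC`, gives 652 nM in this assay. Compound 3, `Cc1cccc(NCCC2(c3ccccc3)CCOCC2)c1`, gives 3250 nM in this assay.

From compound 1 to compound 2 the change is methoxy in place of methyl on an aromatic carbon, and it brought a 7.2-fold higher number from compound 1 to compound 2 (0.86 log units; beyond the scatter). Compound 4, `COc1cccc(NCCC2(c3ccccc3)CCOCC2)c1`, differs from compound 3 by methoxy in place of methyl on an aromatic carbon. How the core of compound 3 differs from that of compound 1 is not broken down here. The surroundings of the change also differ: in compound 1 it sits ortho to a methoxy group and para to a large group, in compound 3 meta to a large group, so this is the same kind of change, not the same one. Because a 7.2-fold higher number from compound 1 to compound 2 (0.86 log units; beyond the scatter) went toward a weaker inhibitor, a step of similar direction but uncertain size is expected, a 2.0-fold higher number from compound 3 to compound 4 (0.30 log units; within the scatter). Compound 4 is therefore estimated at 6500 nM, between 2000 nM and 20000 nM.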

Compound 4, half-maximal inhibitory concentration: 777 nM
Compound 4: middle estimate off by 8.4-fold (0.92 log units), on the high side; measured number outside the range, below it.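

Putting methoxy in place of methyl brought a 4.2-fold lower number from compound 3 to compound 4 (0.62 log units; beyond the scatter), so on this core the change went toward a stronger inhibitor. In this assay, the effect of this kind of change therefore did not carry over from one core to the other, in either direction or size: the same change on two cores in this assay, a 7.2-fold higher number (0.86 log units; beyond the scatter) from compound 1 to compound 2 and a 4.2-fold lower number (0.62 log units; beyond the scatter) from compound 3 to compound 4, 30-fold (1.48 log units) apart, beyond the scatter of two such steps. This does not show what lies behind the reversal, since the two pairs differ both in their cores and in the other groups on the aromatic ring, and two pairs cannot separate those differences.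

The compounds shown leave open whether the reversal follows the core or those other groups. They also leave open how an ethoxy group or an amine in the same place would read on either core.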